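A Swap on the Amide Aryl Ring: Expecting Compound 3

This account rests on a few compounds, and the source may have more. Where it says the series, first, only, none or still open, it means among the compounds named here.

Measured in a functional assay on MKN-74 cells (Homo sapiens) for antiproliferative activity, with a stated time of 24 h; on this read-out higher numbers stand for weaker inhibition and lower numbers for stronger inhibition:
Compound 1 `NC(=O)c1c(NC(=O)c2ccccc2F)sc2c1CCN(C(=S)Nc1ccccc1Cl)C2` — 11100 nM
Compound 2 `COc1ccccc1C(=O)Nc1sc2c(c1C(N)=O)CCN(C(=S)Nc1ccccc1Cl)C2` — 20500 nM

Among the compounds with values here, compound 2 and compound 1 give numbers that sit within the scatter of each other; the only measured step, a 1.8-fold higher number from compound 1 to compound 2 (0.27 log units; within the scatter), shows this, so neither can be called the stronger inhibitor in this assay. Compound 3 `NC(=O)c1c(NC(=O)c2ccc(C(F)(F)F)cc2)sc2c1CCN(C(=S)Nc1ccccc1Cl)C2` has not yet been measured. It differs from compound 2 in one place: 4-(trifluoromethyl)phenyl in place of 2-methoxyphenyl on a carbonyl carbon. Within the data shown here, the single measured step from compound 1 to compound 2 is the only one that bears on this change, since it also swaps the aryl group on that carbonyl carbon, and it was small. Among the measured compounds shown here, no measured pair shows what a 4-(trifluoromethyl)phenyl group does on this core, so there is no ground for expecting a step beyond the scatter in either direction. Compound 3 is therefore expected to stay near its neighbours, with an estimated step of a 1.4-fold lower number from compound 2 to compound 3 (0.14 log units; within the scatter). The estimate for compound 3 in this assay is 15000 nM, with a range from 5000 nM to 45000 nM.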

Compound 3, half-maximal inhibitory concentration: 16400 nM
The estimate for compound 3 lay 1.1-fold (0.04 log units) below the measured number; the measured number falls inside the stated range.
By their numbers in this assay, from the lowest: compounds 1, 3 and 2 (each within the scatter of the next).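

Across the three compounds, the aryl group on this carbonyl carbon has now been changed again in this assay: 4-(trifluoromethyl)phenyl in place of 2-methoxyphenyl gives a 1.3-fold lower number from compound 2 to compound 3 (0.10 log units; within the scatter) and 4-(trifluoromethyl)phenyl in place of 2-fluorophenyl gives a 1.5-fold higher number from compound 1 to compound 3 (0.17 log units; within the scatter). Within the data shown here, the earlier pair showed only two aryl groups, each with a single group at the 2 position of its name, whereas the new group carries trifluoromethyl at the 4 position and lacks the hydrogen-bond acceptor counted on 2-methoxyphenyl, yet all three compounds stay within the scatter of one another in this assay. Nothing measured on these compounds gives a reason for steps this small.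

Going by these compounds, all three compounds keep an aryl group at this place, so it remains open whether something other than an aryl group, such as a longer alkyl chain or a chain ending in an amine or a carboxylic acid, would give a step beyond the scatter. The rest of the molecule is the same in all three, so these compounds also cannot tell whether changes elsewhere would matter more than this one.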